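This account rests on a few compounds, and the source may have more. Where it says the series, first, only, none or still open, it means among the compounds named here.

Compound 1 `CC1=C(C(=O)OC2CCCC2)C(c2ccco2)NC(=O)N1` carries a cyclopentyl ester and a furan-2-yl group on the saturated ring carbon. In an assay on membranes from HeLa cells for displacement of a labelled ligand from adenosine receptor A3 (Homo sapiens), read by scintillation counting, with a stated time of 180 min, tested at 1 uM (a lower number here means less inhibition, a higher number more inhibition at the concentration tested (going by the name of the read-out)), compound 1 gives 14%. Compound 2 `CC1=C(C(=O)OC2CCCCC2)C(c2ccco2)NC(=O)N1` is the cyclohexyl ester of the same core; in this assay compound 2 gives 4%. The change cyclohexyl in place of cyclopentyl on an oxygen next to a carbonyl group is matched by the step of a number 10 percentage points lower from compound 1 to compound 2 (within the scatter). Compound 3 `CC1=C(C(=O)OC2CCCC2)C(c2ccsc2)NC(=O)N1` keeps the cyclopentyl ester, and in this assay compound 3 gives 5%. The step of a number 9 percentage points lower from compound 1 to compound 3 (within the scatter) goes with the change in the core, (thiophen-3-yl in place of furan-2-yl on a saturated ring carbon).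

Compound 4 `CC1=C(C(=O)OC2CCCCC2)C(c2ccsc2)NC(=O)N1` has not yet been measured in this assay. It differs from compound 3 by cyclohexyl in place of cyclopentyl on an oxygen next to a carbonyl group, the same change that separates compound 2 from compound 1, made here on a core that differs from that of compound 1 by the thiophen-3-yl in place of the furan-2-yl. The expectation for the step of a number 2 percentage points lower from compound 3 to compound 4 (within the scatter) rests on the step of a number 10 percentage points lower from compound 1 to compound 2 (within the scatter) seen for compound 1 and compound 2, which stayed within the scatter. On that basis compound 4 is estimated at 3% in this assay, expected to lie between -8% and 14%.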

Compound 4, a percentage reported as inhibition, at one concentration (the size of the read-out at that concentration, not a potency): 1%
Compound 4: the middle estimate sits 2 percentage points above what was measured, within the range that was stated.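

In this assay, cyclohexyl in place of cyclopentyl on an oxygen next to a carbonyl group now goes with a number 4 percentage points lower from compound 3 to compound 4 (within the scatter), which can be set beside the earlier step for the same change: the same change on two cores in this assay, a number 10 percentage points lower (within the scatter) from compound 1 to compound 2 and a number 4 percentage points lower (within the scatter) from compound 3 to compound 4, 6 percentage points apart, within the scatter of two such steps. Thiophen-3-yl in place of furan-2-yl on a saturated ring carbon goes with a number 3 percentage points lower from compound 2 to compound 4 (within the scatter), and it too can be set beside its earlier step: the same change on two cores in this assay, a number 9 percentage points lower (within the scatter) from compound 1 to compound 3 and a number 3 percentage points lower (within the scatter) from compound 2 to compound 4, 6 percentage points apart, within the scatter of two such steps. Each change therefore reads the same on the two cores shown, but every one of these steps lies within the scatter, so this shows neither that either change alters the read-out nor that the agreement would hold on any further core.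

The compounds shown leave open what a longer chain or an amine on the ester would do, or a phenyl ring in place of the furan-2-yl or thiophen-3-yl. They also give no potency, only the size of the read-out at one concentration.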